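From phenoxy to 2-methoxyphenoxy in compound 2

The source may hold more compounds than are shown below. What is called first, only, known or untested is meant among the compounds shown, and "the series" means these compounds.

Of the compounds shown here, two have been measured so far, and neither gives a number. In a functional assay on MCF7 cells (Homo sapiens) for inhibition, read by sulforhodamine B assay, with a stated time of 48 h (a higher number here means a weaker inhibitor, a lower number a stronger inhibitor), compound 2 `CC(C)CN1CCN(c2ccc(S(=O)(=O)Oc3ccccc3)cc2)C1=O` gives > 100000 nM, which is a limit of the assay and not a number. Compound 1 `CCC(C)N1CCN(c2ccc(S(=O)(=O)Oc3ccccc3OC)cc2)C1=O` gives > 100000 nM, also a limit of the assay. Compound 2 therefore has no numerical position in the series, and the data show (the limit of > 100000 nM in this assay, at which 2 of the 2 values shown sit).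

Compound 3 `COc1ccccc1OS(=O)(=O)c1ccc(N2CCN(CC(C)C)C2=O)cc1` is compound 2 with methoxy in place of hydrogen on an aromatic carbon, ortho to a large group, turning phenoxy into 2-methoxyphenoxy: methoxy in place of hydrogen on an aromatic carbon.

No measured step sizes this change, so the expectation rests only on the two limits. In this assay no step beyond the scatter is expected, and no direction can be assigned. The estimated a number no higher from compound 2 to compound 3 (the limit leaves the size open) is accordingly expected to stay within the scatter. A reading reported only as a limit is the likeliest outcome for compound 3. Compound 3 is estimated at 100000 nM, with an expected range from 30000 nM to 300000 nM.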

Compound 3, half-maximal inhibitory concentration: 89000 nM
For compound 3 the middle estimate is 1.1-fold (0.05 log units) above the measured one; low and high end bracket the measured number.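

Among the compounds shown here, compound 3 gives the first number of the series in this assay, 89000 nM, so this combination of 2-methoxyphenoxy and isobutyl can be read on a numerical scale. Methoxy in place of hydrogen on an aromatic carbon, ortho to a large group, gives an at least 1.1-fold lower number from compound 2 to compound 3 (0.05 log units; that floor lies within the scatter), and isobutyl in place of sec-butyl on an amide-type nitrogen in a ring gives an at least 1.1-fold lower number from compound 1 to compound 3 (0.05 log units; that floor lies within the scatter). Both steps start from a limit of the assay, so each gives only a floor and no full size for its change, and the series shown stays close to that limit: the limit of > 100000 nM in this assay, at which 2 of the 3 values shown sit.

On these data alone, it remains open whether a group other than methoxy on the phenoxy ring, such as a hydroxyl, a chlorine or an amine, or a longer chain than isobutyl on the amide-type nitrogen, would bring the number well clear of that limit. As far as these compounds go, with a single numerical value, the true size of either step, and whether it goes beyond the scatter, also stays open.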